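A few compounds are considered here, and "the series" means these few. Any claim that something is new, unique, unknown or untested is made for them only; others in the source may bear on it.

In a functional assay on RAW264.7 cells (Mus musculus) for inhibition, read by Griess assay, with stated times of 1 h and 24 h (on this read-out higher numbers stand for weaker inhibition and lower numbers for stronger inhibition), compound 1 `CCCCCOc1ccccc1C1CC(=O)c2ccccc2O1` gives 39200 nM and compound 2 `CC(C)=CCOc1ccccc1C1CC(=O)c2ccccc2O1` gives 32700 nM, so compound 2 stands level with compound 1 within the scatter. Compound 3 `O=C1CC(c2ccccc2OCc2cccc(F)c2)Oc2ccccc21` follows from compound 2 by 3-fluorophenyl in place of 2-methylprop-1-en-1-yl on a saturated chain carbon bound to an oxygen on an aromatic ring, the same difference read as 3-methylbut-2-en-1-yl to 3-fluorobenzyl. Among the measured compounds shown here, the only measured step bearing on this is a 1.2-fold lower number from compound 1 to compound 2 (0.08 log units; within the scatter), and no measured step brings in a ring at this place, so the evidence is thin. The expected change is a 1.2-fold lower number from compound 2 to compound 3 (0.07 log units; within the scatter), with none expected beyond the scatter. For compound 3 the estimated value is 28000 nM, with an expected range of 11000 nM to 65000 nM.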

Compound 3, half-maximal inhibitory concentration: 15600 nM
Beside the measured number, compound 3's estimate is 1.8-fold (0.25 log units) above it; the measured number falls inside the stated range.
By their numbers in this assay, from the lowest: compound 3; then compounds 2 and 1 (each within the scatter of the next).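

Among the compounds shown here, at the saturated chain carbon bound to an oxygen on an aromatic ring, a ring now enters for the first time: in this assay 3-fluorophenyl brings a 2.1-fold lower number from compound 2 to compound 3 (0.32 log units; beyond the scatter) and a 2.5-fold lower number from compound 1 to compound 3 (0.40 log units; beyond the scatter) while the earlier exchange of butyl for 2-methylprop-1-en-1-yl stayed within the scatter. This place therefore does respond to the change, though only modestly. No measurement available here accounts for the shift. On these data alone, whether the step belongs to the ring or to the fluorine stays open, and a plain benzyl group would separate the two. As far as these compounds go, how an amine or a carboxylic acid at this place would read also stays open.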